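Oxolan-3-yl replacing 1-methylpiperidin-4-yl at the triazole nitrogen

This account rests on a few compounds, and the source may have more. Where it says the series, first, only, none or still open, it means among the compounds named here.

Compound 3 `CN1CCC(n2nnc3c2CCC(c2nc(-c4ccc(F)cc4)no2)C3)CC1` gives 91% in a functional assay on U2OS cells with metabotropic glutamate receptor 5 (Homo sapiens) as the target, read by calcium flux (a lower number here means a smaller maximal response, a higher number a larger maximal response), the lowest of the two single numbers in the set; the nearest is compound 2 `Fc1ccc(-c2noc(C3CCc4c(nnn4-c4ccc(F)cc4)C3)n2)cc1` with 106%, and compound 1 `Fc1ccc(-c2noc(C3CCc4c(nnn4C4CCCC4)C3)n2)cc1` has two entries, 78%; 103% (2 entries), with no single number. Among the compounds with values here, the only step measured in one place is a number 15 percentage points lower from compound 2 to compound 3 (beyond the scatter), which is modest and beyond the scatter. Compound 4 `Fc1ccc(-c2noc(C3CCc4c(nnn4C4CCOC4)C3)n2)cc1` differs from compound 3 by oxolan-3-yl in place of 1-methylpiperidin-4-yl on an aromatic nitrogen. Within the data shown here, no measured step covers this exchange of one non-aromatic ring for another at the same aromatic nitrogen. Compound 1, which also carries a non-aromatic group there, spans a wide band in the several entries of compound 1 in this assay, 78%; 103% (2 entries). The expectation for compound 4 is therefore a change of a number 4 percentage points higher from compound 3 to compound 4 (within the scatter) in this assay, not beyond the scatter, with the wide spread of compound 1 setting the range. Compound 4 is estimated at 95%, between 75% and 115%.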

Compound 4, largest response reached (reported as percent of maximum), in percent of the reference or control that the assay uses: 96%
Beside the measured number, compound 4's estimate is 1 percentage points below it; the measured number falls inside the stated range.
By their numbers in this assay, from the lowest: compounds 3, 4 and 2 (each within the scatter of the next, the first and the last beyond it).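

In this assay, exchanging one non-aromatic ring for another on the aromatic nitrogen leaves the maximal response within the scatter, with a number 5 percentage points higher from compound 3 to compound 4 (within the scatter). This holds even though the five-membered ring with its ring oxygen replaces a six-membered ring with its ring nitrogen. Within the data shown here, compound 4 also stands within the scatter of the 4-fluorophenyl compound, with a number 10 percentage points lower from compound 2 to compound 4 (within the scatter), so a non-aromatic ring at this position does not by itself set the response apart from an aromatic one, and a number 15 percentage points lower from compound 2 to compound 3 (beyond the scatter) remains the only step here beyond the scatter.

As far as these compounds go, whether an open alkyl chain or a carboxylic acid on this nitrogen would hold the response in the same band remains open. The place of compound 1 in this order also stays unsettled, as it has no single number: the several entries of compound 1 in this assay, 78%; 103% (2 entries)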